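Furan amides under a cytotoxicity readout

This account rests on a few compounds, and the source may have more. Where it says the series, first, only, none or still open, it means among the compounds named here.

Compound 1 `C/C(=C\c1cc(-c2ccc(C)cc2)co1)C(N)=O` carries a methyl group on its pendant aromatic ring; compound 2 `C/C(=C\c1cc(-c2ccc(F)cc2)co1)C(N)=O` carries a fluoro group in its place. The difference between them is fluoro in place of methyl on an aromatic carbon. In a functional assay on T-24 cells (Homo sapiens) for cytotoxicity, read by CCK-8 assay, with a stated time of 24 h (on this read-out higher numbers stand for weaker inhibition and lower numbers for stronger inhibition), compound 1 reaches only the limit of the measurement, > 50000 nM. In this assay compound 2 likewise returns a limit, > 50000 nM. The step that the two limits leave unreadable from compound 1 to compound 2 therefore cannot be sized, because both numbers rest on (the limit of > 50000 nM in this assay, at which 3 of the 3 values shown sit).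

Compound 3 `C/C(=C\c1ccc(-c2ccc(C)cc2)o1)C(N)=O` shares all its atoms with compound 1, joined differently; the difference between the two cores is not broken down here. In this assay compound 3 again gives a limit, > 50000 nM.

Compound 4 `C/C(=C\c1ccc(-c2ccc(F)cc2)o1)C(N)=O` is not yet measured. It differs from compound 3 by fluoro in place of methyl on an aromatic carbon, the same change as that from compound 1 to compound 2. Since every value shown sits at the limit, the step is expected to be a step that the limit leaves unreadable from compound 3 to compound 4, and compound 4 is estimated at 60000 nM in this assay, most probably reported as a limit once more.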

Compound 4, half-maximal inhibitory concentration: 3320 nM
Estimate against measurement, compound 4: 18-fold (1.26 log units) above, and the stated range ends above it.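

On the core of compound 3 in this assay, fluoro in place of methyl on an aromatic carbon gives an at least 15-fold lower number from compound 3 to compound 4 (1.17 log units; beyond the scatter), a large step beyond the scatter, and its size is itself bounded only on one side since compound 3 is a limit. For the compounds shown here, on the core of compound 1 the same change leaves compound 2 at a limit, > 50000 nM, so a measurable value appears with fluoro on only one of the two cores. This does not show that the change fails to carry over, since the step on the core of compound 1 cannot be read and could be small or large, with both of its values resting on the same ceiling: the limit of > 50000 nM in this assay, at which 3 of the 4 values shown sit.

The compounds shown leave open whether the measured value of compound 4 depends on fluoro specifically or whether a chloro or methoxy group in the same place on that core would also give a number below the limit. They also leave open how the value would respond if the amide gave way to a carboxylic acid.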